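A few compounds are considered here, and "the series" means these few. Any claim that something is new, unique, unknown or untested is made for them only; others in the source may bear on it.

Compound 2 `COc1cc(F)ccc1N1C(=O)CSC1c1cccc(C(=O)NCCCCc2ccccc2)c1` stands highest of the two numbers measured here: in a functional assay on 143B cells (Homo sapiens) for inhibition, read by CCK-8 assay, with a stated time of 72 h, tested at 1 uM (a lower number here means less inhibition, a higher number more inhibition at the concentration tested (going by the name of the read-out)), compound 2 gives 63%, while compound 1 `CCN1C(=O)CSC1c1cccc(C(=O)NCCCCc2ccccc2)c1` gives 40%, a change of a number 23 percentage points higher from compound 1 to compound 2 (beyond the scatter). Compound 3 `COc1c(F)cccc1N1C(=O)CSC1c1cccc(C(=O)NCCCCc2ccccc2)c1` differs from compound 2 only in this way: 3-fluoro-2-methoxyphenyl in place of 4-fluoro-2-methoxyphenyl on an amide-type nitrogen in a ring. Going by the values given here, the single measured step exchanged an ethyl group for a 4-fluoro-2-methoxyphenyl group on that ring nitrogen, a much larger alteration than shifting one fluorine within an aromatic ring that is already present; no measured pair shows what such a shift does in this assay. Among the compounds with values here, because the only evidence is that step, and it does not mirror the present change, compound 3 is expected to land close to compound 2, with the step of a number 3 percentage points lower from compound 2 to compound 3 (within the scatter) staying within the scatter of repeated measurements. Compound 3 is therefore estimated at 60%, with a plausible range from 45% to 75%.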

Compound 3, a percentage reported as inhibition, at one concentration (the size of the read-out at that concentration, not a potency): 5%
For compound 3 the middle estimate is 55 percentage points above the measured one; the whole stated range lies above it.
By their numbers in this assay, from the lowest: compound 3; then compound 1; then compound 2.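

In this assay, moving a single fluorine while keeping the same atoms gives a number 58 percentage points lower from compound 2 to compound 3 (beyond the scatter), so what counts on this ring nitrogen is not only which atoms the group holds but how they are arranged on the phenyl ring. Placing an aromatic ring there does not in itself raise inhibition: there is a number 35 percentage points lower from compound 1 to compound 3 (beyond the scatter), which leaves the 3-fluoro-2-methoxyphenyl group behind plain ethyl, and compound 2 is the one that goes the other way. No measured information on the compounds explains this drop.

The compounds shown leave open how a plain phenyl group or a 2-methoxyphenyl group with no fluorine would compare on this nitrogen. That comparison would indicate whether the 4-fluoro group adds inhibition, the 3-fluoro group removes it, or both.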